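Sulfonamide series: pyrrolidine amide in place of imidazolylmethyl

This account rests on a few compounds, and the source may have more. Where it says the series, first, only, none or still open, it means among the compounds named here.

Measured so far in an assay on isolated protein for binding affinity to secreted frizzled-related protein 1 (Homo sapiens), read by fluorescence; a lower number here means a stronger inhibitor, a higher number a weaker inhibitor:
compound 1 `O=C(Cn1ccnc1)N1CCC(NS(=O)(=O)c2cc(S(=O)(=O)c3ccccc3)ccc2C(F)(F)F)CC1`, 30 nM
compound 2 `CC(C)(C)NC(=O)N1CCC[C@H]1C(=O)N1CCC(NS(=O)(=O)c2cc(S(=O)(=O)c3ccccc3)ccc2C(F)(F)F)CC1`, 20 nM
compound 3 `O=C([C@@H]1CCCN1C(=O)Nc1ccccc1)N1CCC(NS(=O)(=O)c2cc(S(=O)(=O)c3ccccc3)ccc2C(F)(F)F)CC1`, 20 nM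

Compound 1 lies within the scatter of both compound 2 and compound 3; in this assay the step of a 1.5-fold lower number from compound 1 to compound 2 (0.18 log units; within the scatter) and the step of no change at the digits printed from compound 2 to compound 3 (within the scatter) are both inside the usual noise, so none of the three is separated from the others.

Compound 4 `CC(C)(C)CCN1CCC[C@H]1C(=O)N1CCC(NS(=O)(=O)c2cc(S(=O)(=O)c3ccccc3)ccc2C(F)(F)F)CC1` differs from compound 1 by 1-(3,3-dimethylbutyl)pyrrolidin-2-yl in place of (1H-imidazol-1-yl)methyl on a carbonyl carbon. Among the compounds with values here, the one step that bears on it is a 1.5-fold lower number from compound 1 to compound 2 (0.18 log units; within the scatter), where a pyrrolidin-2-yl group also entered on the same carbonyl carbon with no movement beyond the scatter. The further change in compound 4 is at the pyrrolidine nitrogen, where the step of no change at the digits printed from compound 2 to compound 3 (within the scatter) also showed nothing. Compound 4 is therefore expected to give 25 nM (range 10 nM to 60 nM) in this assay, the expected step of a 1.2-fold lower number from compound 1 to compound 4 (0.08 log units; within the scatter) staying within the scatter.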

Compound 4, half-maximal inhibitory concentration: 30 nM
Estimate against measurement, compound 4: 1.2-fold (0.08 log units) below, within the range that was stated.
By their numbers in this assay, from the lowest: compounds 2, 3, 1 and 4 (each within the scatter of the next).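

In this assay, 3,3-dimethylbutyl on the amine nitrogen in a ring can stand in for either carbamoyl group without leaving the scatter (a 1.5-fold higher number from compound 3 to compound 4 (0.18 log units; within the scatter)) (a 1.5-fold higher number from compound 2 to compound 4 (0.18 log units; within the scatter)), so neither carbamoyl group is needed at this position to hold the number. On the carbonyl carbon, the 1-(3,3-dimethylbutyl)pyrrolidin-2-yl group, with no hydrogen-bond donor, also matches (1H-imidazol-1-yl)methyl (no change at the digits printed from compound 1 to compound 4 (within the scatter)). No available measurement accounts for this flat response.

On these data alone, whether a primary amine, a carboxylic acid or a longer chain on that nitrogen would move the number beyond the scatter remains open.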